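A few compounds are considered here, and "the series" means these few. Any claim that something is new, unique, unknown or untested is made for them only; others in the source may bear on it.

Compound 1 `O=C(/C=C/CN1CCCCC1)Nc1cc2c(N3CCc4ccccc43)ncnc2cc1O[C@@H]1CCOC1` and compound 2 `CN1CCN(C/C=C/C(=O)Nc2cc3c(N4CCc5ccccc54)ncnc3cc2O[C@@H]2CCOC2)CC1` share one core, and compound 3 `COc1cc2ncnc(N3CCCc4ccccc43)c2cc1NC(=O)/C=C/CN1CCCCC1` and compound 4 `COc1cc2ncnc(N3CCCc4ccccc43)c2cc1NC(=O)/C=C/CN1CCN(C)CC1` share another; how the two cores differ is not broken down here. In a functional assay on PC-3 cells (Homo sapiens) for antiproliferative activity, read by MTT assay, with a stated time of 72 h (a lower number here means a stronger inhibitor, a higher number a weaker inhibitor), compound 1 gives 4510 nM, compound 2 gives 4210 nM, and compound 3 gives 5780 nM. Within the first core, the change 4-methylpiperazin-1-yl in place of piperidin-1-yl on a saturated chain carbon bound to a double-bonded chain carbon gave a 1.1-fold lower number from compound 1 to compound 2 (0.03 log units; within the scatter). The same change, (4-methylpiperazin-1-yl in place of piperidin-1-yl on a saturated chain carbon bound to a double-bonded chain carbon), is made within the second core. Because a 1.1-fold lower number from compound 1 to compound 2 (0.03 log units; within the scatter) stayed within the scatter, the step from compound 3 to compound 4 is expected to be about as small, roughly a 1.1-fold lower number from compound 3 to compound 4 (0.03 log units; within the scatter). Compound 4 is therefore expected to give about 5400 nM in this assay, most likely between 2700 nM and 10800 nM.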

Compound 4, half-maximal inhibitory concentration: 6260 nM
Compound 4: middle estimate off by 1.2-fold (0.06 log units), on the low side; measured number inside the range.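

On the second core, putting 4-methylpiperazin-1-yl in place of piperidin-1-yl leaves the result in this assay essentially unmoved (a 1.1-fold higher number from compound 3 to compound 4 (0.03 log units; within the scatter)). The two cores agree on this change: the same change on two cores in this assay, a 1.1-fold lower number (0.03 log units; within the scatter) from compound 1 to compound 2 and a 1.1-fold higher number (0.03 log units; within the scatter) from compound 3 to compound 4, 1.2-fold (0.06 log units) apart, within the scatter of two such steps. In these two pairs the change carries from one core to the other as a step too small to read, but that shows only that it does little on either core, and a change with so little effect is a weak test of whether effects transfer between cores.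

Still open, as far as these compounds go, is whether another group on the same saturated chain carbon, such as morpholin-4-yl or dimethylamino, would move the number beyond the scatter. Also open, from the compounds shown here alone, is whether this change would stay as small on other cores.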